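This account rests on a few compounds, and the source may have more. Where it says the series, first, only, none or still open, it means among the compounds named here.

In a functional assay on U-937 cells (Homo sapiens) for antiproliferative activity, read by MTT assay, with a stated time of 72 h (on this read-out lower numbers stand for stronger inhibition and higher numbers for weaker inhibition), compound 1 `Cc1ccc(-c2noc(CCCCCCC(=O)NO)n2)cc1` gives 1360 nM. This is the higher of the two numbers available, as compound 2 `O=C(CCCCCCc1nc(-c2cccnc2)no1)NO` gives 350 nM. Compound 3 `Cc1ccc(-c2noc(CCCCCCC(=O)C(F)(F)F)n2)cc1` keeps the core of compound 1 and differs in one place: trifluoromethyl in place of hydroxyamino on a carbonyl carbon. Trifluoromethyl stands in place of hydroxyamino on a carbonyl carbon, so hydroxycarbamoyl becomes (trifluoromethyl)carbonyl. Among the compounds with values here, only one measured step is available, a 3.9-fold lower number from compound 1 to compound 2 (0.59 log units; beyond the scatter), and it is modest. That step swaps pyridin-3-yl for 4-methylphenyl on an aromatic carbon, so it offers a sense of scale in this assay but no direct evidence about the new change. Within the data shown here, no measured compound varies the group on the carbonyl carbon, so the direction remains a judgement based on the structural change alone. Starting from compound 1 at 1360 nM, a larger step than the one to compound 2 is expected, towards a higher number and thus weaker inhibition. The expected change is a 5.9-fold higher number from compound 1 to compound 3 (0.77 log units; beyond the scatter). Compound 3 is estimated at 8000 nM, with an expected range of 2000 nM to 35000 nM.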

Compound 3, half-maximal inhibitory concentration: 3730 nM
The estimate for compound 3 lay 2.1-fold (0.33 log units) above the measured number, and the stated range covers the measured number.
By their numbers in this assay, from the lowest: compound 2; then compound 1; then compound 3.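

Measured in this assay, the group on the carbonyl carbon now has a step of its own: a 2.7-fold higher number from compound 1 to compound 3 (0.44 log units; beyond the scatter), so trifluoromethyl in place of hydroxyamino weakens inhibition by more than the usual scatter, though the step is only modest. Compound 3 still gives a finite number of 3730 nM without the hydroxycarbamoyl group, which shows that this group is not indispensable for a measurable antiproliferative read-out on these cells, and the two changes made to compound 1 now run in opposite directions, since a 3.9-fold lower number from compound 1 to compound 2 (0.59 log units; beyond the scatter) at the aromatic carbon. Nothing available here accounts for the size or direction of the new step.

With only two groups shown on the carbonyl carbon, it remains open how a carboxylic acid, a methyl ketone or a primary amide would compare with hydroxyamino and trifluoromethyl at this position. Also open, going by these compounds, are whether a shorter or longer chain would shift the number and whether pyridin-3-yl in place of 4-methylphenyl would lower it to a similar extent with (trifluoromethyl)carbonyl in place of hydroxycarbamoyl.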